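The compounds below may be only part of what the source reports. "The series", "measured", "known", "first", "only" and "open" are said of these compounds alone.

Working notes, series around the shared core of compound 1.

Compound 1 `COc1ccc(C(=O)/C=C/c2cccc(F)c2)c2c1C=CC(C)(C)O2` is measured in a functional assay on SW-620 cells (Homo sapiens) for antiproliferative activity, read by MTT assay, with a stated time of 24 h (on this read-out lower numbers stand for stronger inhibition and higher numbers for weaker inhibition), only as a limit: compound 1 gives > 10000 nM, which is a limit of the assay and not a number. Compound 2 `COc1ccc(C(=O)/C=C/c2ccc(N(c3ccccc3)c3ccccc3)cc2)c2c1C=CC(C)(C)O2` likewise returns a limit, > 10000 nM. Among the compounds with values here, compound 3 `COc1ccc(C(=O)/C=C/c2cccc(C(F)(F)F)c2)c2c1C=CC(C)(C)O2` is the one compound with a number, 7870 nM. Within the data shown here, the only step between measured compounds differing in one place is an at least 1.2-fold lower number from compound 1 to compound 3 (0.10 log units; that floor lies within the scatter); its floor lies within the scatter, so it shows no clear movement. On the numbers shown compound 1 therefore stands at the limit of > 10000 nM in this assay, at which 2 of the 3 values shown sit, with nothing to place it more finely.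

Compound 4 `COc1ccc(C(=O)/C=C/c2ccccn2)c2c1C=CC(C)(C)O2` carries pyridin-2-yl in place of 3-fluorophenyl on a double-bonded chain carbon bound to a double-bonded chain carbon. Among the measured compounds shown here, no measured step bears on this change; the one step known, trifluoromethyl for fluoro, concerns a different group and gives no direction to borrow. The step that the limit leaves unreadable from compound 1 to compound 4 is therefore expected to stay within the scatter. Compound 4 is expected at 12000 nM, with a range of 4000 nM to 40000 nM, most likely reported again as a limit.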

Compound 4, half-maximal inhibitory concentration: 5000 nM
Compound 4: middle estimate off by 2.4-fold (0.38 log units), on the high side; the measured number falls inside the stated range.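

In this assay, pyridin-2-yl in place of 3-fluorophenyl on a double-bonded chain carbon bound to a double-bonded chain carbon gives a measured number, so this place accepts a ring with a hetero atom and a hydrogen-bond acceptor. The change reads as an at least 2.0-fold lower number from compound 1 to compound 4 (0.30 log units; that floor lies within the scatter), which shows no clear movement on its floor alone. Only a floor can be read because compound 1 is held at a limit of the assay and not at a number: the limit of > 10000 nM in this assay, at which 2 of the 4 values shown sit.

The compounds shown leave open whether the step comes from the ring nitrogen or from the loss of fluoro, a question that a plain phenyl at this place would separate. Going by these compounds, how an amine or a carboxylic acid on this ring would read in this assay also stays open.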